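Compound 3 and a new group on the urea nitrogen

The source may report more compounds than this note shows. Statements on the series, on what has been measured and on what is new or still open speak of the compounds shown alone.

Compound 1 `COc1cc2c(Oc3ccc(NC(=O)Nc4ccccc4C(F)(F)F)cc3)ccnc2cc1OCCCCCCC(=O)NO`: 5280 nM
Compound 2 `COc1cc2c(Oc3ccc(NC(=O)Nc4ccccc4F)cc3)ccnc2cc1OCCCCCCC(=O)NO`: 870 nM
Compound 3 `COc1cc2c(Oc3ccc(NC(=O)Nc4ccc(Cl)c(C(F)(F)F)c4)cc3)ccnc2cc1OCCCCCCC(=O)NO`: 5020 nM
Compound 4 `COc1cc2c(Oc3ccc(NC(=O)N/N=C/c4ccc(F)cc4)cc3)ccnc2cc1OCCCCCCC(=O)NO`: not yet measured

In a functional assay on A549 cells (Homo sapiens) for antiproliferative activity, read by MTT assay (a higher number here means a weaker inhibitor, a lower number a stronger inhibitor), compound 3 gives 5020 nM, which places it at the high end of the three numbers, level with compound 1. The measured steps show a 1.1-fold lower number from compound 1 to compound 3 (0.02 log units; within the scatter), and also a 5.8-fold higher number from compound 2 to compound 3 (0.76 log units; beyond the scatter). The next change is a group of 9 heavy atoms (7 carbon, 1 nitrogen, 1 fluorine; one six-membered aromatic ring of carbon only) in place of a group of 11 heavy atoms (7 carbon, 3 fluorine, 1 chlorine; one six-membered aromatic ring of carbon only), on an amide-type nitrogen, on an amide-type nitrogen whose other neighbours are: carbonyl carbon. Within the data shown here, no measured step introduces this entering group, so the evidence is indirect. Among the three measured compounds, only compound 2 has no trifluoromethyl group, and the step to it is a 6.1-fold lower number from compound 1 to compound 2 (0.78 log units; beyond the scatter). Compound 4 also lacks trifluoromethyl, but its entering group differs much more from the measured ones, so only part of that modest step is expected to carry over. The expected change is a 2.5-fold lower number from compound 3 to compound 4 (0.40 log units; beyond the scatter). Compound 4 is estimated at 2000 nM, with an expected range of 600 nM to 7000 nM.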

Compound 4, half-maximal inhibitory concentration: 4920 nM
For compound 4 the middle estimate is 2.5-fold (0.39 log units) below the measured one; the measured number falls inside the stated range.
By their numbers in this assay, from the lowest: compound 2; then compounds 4, 3 and 1 (each within the scatter of the next).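

In this assay, the new group on the amide-type nitrogen, with its double bond outside the aromatic ring and its hydrogen-bond acceptor, leaves the number in place of the 4-chloro-3-(trifluoromethyl)phenyl group (a 1.0-fold lower number from compound 3 to compound 4 (0.01 log units; within the scatter)), and the same holds against the group of compound 1 (a 1.1-fold lower number from compound 1 to compound 4 (0.03 log units; within the scatter)). The earlier compounds shown here left open whether losing trifluoromethyl at this position was enough to reach the number of compound 2, but compound 4 also lacks trifluoromethyl and still stands apart from compound 2 (a 5.7-fold higher number from compound 2 to compound 4 (0.75 log units; beyond the scatter)). Nothing available explains this result.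

The compounds shown leave open whether a 4-fluorophenyl group or an unsubstituted phenyl group placed directly on the amide-type nitrogen would match compound 2 or compound 4. They also leave open whether the double bond in the entering group matters, which a saturated chain carrying the same 4-fluorophenyl group could test.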